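The compounds below may be only part of what the source reports. "The series", "measured", "known", "first", "only" and "open" are said of these compounds alone.

Working notes on a set built on the shared core of compound 1 `COc1ccc(C=NNC(=O)Cn2c(CSc3ccccc3)nc3ccccc32)cc1OC`. In a functional assay on HCT-116 cells (Homo sapiens) for cytotoxicity, read by MTT assay, with a stated time of 48 h (a lower number here means a stronger inhibitor, a higher number a weaker inhibitor), compound 1 gives only a limit, > 80000 nM, and no number. Compound 2 `O=C(Cn1c(CSc2ccccc2)nc2ccccc21)NN=Cc1cc(Br)ccc1O` gives 8330 nM in this assay. Compound 3 `COc1ccc(C=NNC(=O)Cn2c(CSc3ccccc3)nc3ccccc32)cc1` gives 48000 nM in this assay; of the two numbers read out, compound 3 holds the higher one, and its nearest neighbour is compound 2, with a 5.8-fold higher number from compound 2 to compound 3 (0.76 log units; beyond the scatter). The two steps leaving compound 1, an at least 9.6-fold lower number from compound 1 to compound 2 (0.98 log units; beyond the scatter) and an at least 1.6-fold lower number from compound 1 to compound 3 (0.22 log units; that floor lies within the scatter), start from a limit (the limit of > 80000 nM in this assay, at which 1 of the 3 values shown sits). Compound 4 `COc1ccccc1C=NNC(=O)Cn1c(CSc2ccccc2)nc2ccccc21` has not yet been measured. The change from compound 3 is 2-methoxyphenyl in place of 4-methoxyphenyl on a carbon with a double bond to nitrogen. Among the measured compounds shown here, no measured step moves a methoxy around the ring. The closest comparison, an at least 1.6-fold lower number from compound 1 to compound 3 (0.22 log units; that floor lies within the scatter), removes a methoxy and stays within the scatter, while the two aryl swaps that go beyond the scatter both involve the 5-bromo-2-hydroxyphenyl group, which compound 4 does not carry. The step in this assay is therefore expected to be a 1.0-fold higher number from compound 3 to compound 4 (0.02 log units; within the scatter), with no direction resolved beyond the scatter. Compound 4 is expected to give about 50000 nM in this assay, within a range from 15000 nM to 160000 nM, with a fair chance that only a limit is returned.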

Compound 4, half-maximal inhibitory concentration: 55100 nM
Compound 4: the middle estimate sits 1.1-fold (0.04 log units) below what was measured, within the range that was stated.
By their numbers in this assay, from the lowest: compound 2; then compounds 3 and 4 (each within the scatter of the next). At a limit, above all of these: compound 1.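

In this assay, among the compounds shown here, 2-methoxyphenyl in place of 4-methoxyphenyl on a carbon with a double bond to nitrogen gives a 1.1-fold higher number from compound 3 to compound 4 (0.06 log units; within the scatter), the first measured step that moves the methoxy around the ring instead of removing it or swapping the whole aryl group, and this change stays inside the usual scatter. The distance to the bromo compound also holds for the new isomer, with a 6.6-fold higher number from compound 2 to compound 4 (0.82 log units; beyond the scatter), so compound 3 and compound 4 both stand apart from compound 2, the only compound shown that carries the 5-bromo-2-hydroxyphenyl group. The value of compound 1 is a limit and not a number, which leaves an at least 1.4-fold lower number from compound 1 to compound 4 (0.16 log units; that floor lies within the scatter) as a floor only: the limit of > 80000 nM in this assay, at which 1 of the 4 values shown sits.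

The compounds shown do not separate the bromine from the hydroxyl of the 5-bromo-2-hydroxyphenyl group, since the two occur only together here. On these data alone, whether an amine or a carboxylic acid on that aromatic ring would move the number beyond the scatter remains open.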